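Ester variation on the shared core: compound 3 to compound 4

The source may report more compounds than this note shows. Statements on the series, on what has been measured and on what is new or still open speak of the compounds shown alone.

Measured in a functional assay on HEK293 cells for antagonist activity at Voltage-dependent L-type calcium channel subunit alpha-1C (Oryctolagus cuniculus), read by FLIPR; on this read-out higher numbers stand for weaker inhibition and lower numbers for stronger inhibition:
- compound 1 `CCOC(=O)C1=C(C)NC(COC)=C(C(=O)OC)C1c1ccccc1[N+](=O)[O-]` gives 1760 nM
- compound 2 `C=CCOC(=O)C1=C(C)NC(C)=C(C(=O)OCC)C1c1cccc([N+](=O)[O-])c1` gives 25 nM
- compound 3 `C#CCCOC(=O)C1=C(C)NC(C)=C(C(=O)OC)C1c1cccc([N+](=O)[O-])c1` gives 31 nM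

Compound 3 stands second highest of the three numbers. Its nearest neighbour is compound 2, whose value lies within the scatter of that of compound 3, so no order between the two can be read. Compound 1 lies far above compound 3, beyond the scatter.

Compound 4 `COC(=O)C1=C(C)NC(C)=C(C(=O)OC2C=CCCC2)C1c1cccc([N+](=O)[O-])c1` differs from compound 3 in one place: cyclohex-2-en-1-yl in place of but-3-yn-1-yl on an oxygen next to a carbonyl group. Among the measured compounds shown here, no pair of measured compounds isolates this change, so nothing fixes its size. The step from compound 3 to compound 4 is therefore expected to be small, a 1.0-fold lower number from compound 3 to compound 4 (0.01 log units; within the scatter), with no direction claimed beyond the scatter. Compound 4 is estimated at 30 nM in this assay, in a range from 8 nM to 120 nM.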

Compound 4, half-maximal inhibitory concentration: 10 nM
Compound 4: middle estimate off by 3.0-fold (0.48 log units), on the high side; the measured number falls inside the stated range.
By their numbers in this assay, from the lowest: compound 4; then compounds 2 and 3 (each within the scatter of the next); then compound 1.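

On the oxygen next to the carbonyl group, a six-membered carbon ring is compatible with stronger inhibition than the open but-3-yn-1-yl chain in this assay (a 3.1-fold lower number from compound 3 to compound 4 (0.49 log units; beyond the scatter)). Among the compounds shown here, this is the first change in one place that can be read, so its size rests on this single pair. Nothing at hand accounts for the step.

Still open, from the compounds shown here alone, is whether the ring, the double bond or the larger carbon count carries the step. Cyclohexyl or hexyl on the same oxygen would separate these.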